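The compounds below may be only part of what the source reports. "The series", "measured", "known", "first", "only" and "open" are said of these compounds alone.

Compound 1 `O=C(CCCc1ccccc1)Nc1nc2ccccc2c(=O)s1` and compound 3 `O=C(C/C=C/c1ccccc1)Nc1nc2ccccc2c(=O)s1` share a core and differ in the chain that joins it to the phenyl ring; that difference is not broken down here. In an in vitro assay on cells for inhibition of Amine oxidase [flavin-containing] B (Homo sapiens), read by fluorescence and Amplex Red, with stated times of 30 min and 45 min (on this read-out higher numbers stand for weaker inhibition and lower numbers for stronger inhibition), compound 1 gives 34.9 nM, and compound 3 gives 39.8 nM. Compound 2 `O=C(C/C=C/c1cccc(Cl)c1)Nc1nc2ccccc2c(=O)s1` carries, relative to compound 3, the change (chloro in place of hydrogen on an aromatic carbon). In this assay compound 2 reaches only a limit, > 1000 nM, the point (the limit of > 1000 nM in this assay, at which 1 of the 3 values shown sits). The step of an at least 25-fold higher number from compound 3 to compound 2 (1.40 log units; beyond the scatter) is large. Compound 4 `O=C(CCCc1ccccc1)Nc1nc2cc(Cl)ccc2c(=O)s1` awaits measurement in this assay and carries, relative to compound 1, the change (chloro in place of hydrogen on an aromatic carbon). This is the same kind of change, not the same: the earlier chloro sits meta to a large group, the new one on a ring that is part of a fused or bridged system of two rings, meta to a fused ring and para to a fused ring. Going by the values given here, the step of a 2.6-fold higher number from compound 1 to compound 4 (0.41 log units; beyond the scatter) is expected to be smaller than the earlier one, since the only guide is an at least 25-fold higher number from compound 3 to compound 2 (1.40 log units; beyond the scatter) at a different place. Compound 4 is estimated at 90 nM, between 25 nM and 450 nM.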

Compound 4, half-maximal inhibitory concentration: 76.4 nM
The estimate for compound 4 lay 1.2-fold (0.07 log units) above the measured number; the measured number falls inside the stated range.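

In this assay, chloro in place of hydrogen on an aromatic carbon gives a higher number in both pairs, but the new step, a 2.2-fold higher number from compound 1 to compound 4 (0.34 log units; beyond the scatter), is modest, and the size of the earlier step did not carry over: the same change on two cores in this assay, an at least 25-fold higher number (1.40 log units; beyond the scatter) from compound 3 to compound 2 and a 2.2-fold higher number (0.34 log units; beyond the scatter) from compound 1 to compound 4, at least 11-fold (1.05 log units) apart, beyond the scatter of two such steps. The number for compound 2, > 1000 nM, is a limit of the assay, so that gap is known from one side only. The two chloro groups sit on different rings and the chains also differ, so these pairs do not show which of these sets the size of the step.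

The compounds shown leave open how chloro behaves on the phenyl ring of compound 1 or on the fused ring of compound 3. They also leave open whether fluoro or methoxy at these places, or a longer chain, would follow the same course.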